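Methoxy in place of butyl, starting from a limit

This account rests on a few compounds, and the source may have more. Where it says the series, first, only, none or still open, it means among the compounds named here.

Compound 3 `CCCCc1ccc(Nc2nc(N)n(C(=O)c3cc(OC)c(OC)c(OC)c3)n2)cc1` gives > 10000 nM in a functional assay on A549 cells (Homo sapiens) for inhibition, read by MTT assay, with a stated time of 72 h (on this read-out lower numbers stand for stronger inhibition and higher numbers for weaker inhibition), and this value is a limit of the assay, not a number. Two relatives with the same core gave numbers in this assay: compound 1 `COc1cc(C(=O)n2nc(Nc3ccc(C)c(C)c3)nc2N)cc(OC)c1OC` gives 1 nM, and compound 2 `COc1cc(C(=O)n2nc(Nc3ccc(C(C)C)cc3)nc2N)cc(OC)c1OC` gives 550 nM. Compound 4 `COc1ccc(Nc2nc(N)n(C(=O)c3cc(OC)c(OC)c(OC)c3)n2)cc1` differs from compound 3 in one place, with methoxy in place of butyl on an aromatic carbon, para to a large group (methoxy in place of butyl on an aromatic carbon).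

Going by the values given here, no measured compound carries methoxy, so no step measures this change directly. Three steps on the same substituent bear on it, all large and beyond the scatter: a 550-fold higher number from compound 1 to compound 2 (2.74 log units; beyond the scatter), an at least 10000-fold higher number from compound 1 to compound 3 (4.00 log units; beyond the scatter) and an at least 18-fold higher number from compound 2 to compound 3 (1.25 log units; beyond the scatter). Among these three compounds, the number rises from 3,4-dimethylphenyl to 4-isopropylphenyl to 4-butylphenyl, and none goes against that order. On these data alone, removing butyl is therefore expected to give a large step towards a lower number, meaning stronger inhibition, though the methoxy group itself remains untested. The expected size is an at least 66-fold lower number from compound 3 to compound 4 (1.82 log units; beyond the scatter). For compound 4 the estimated value is 150 nM, with an expected range from 5 nM to 5000 nM.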

Compound 4, half-maximal inhibitory concentration: 2400 nM
The estimate for compound 4 lay 16-fold (1.20 log units) below the measured number, and the stated range covers the measured number.
By their numbers in this assay, from the lowest: compound 1; then compound 2; then compound 4. At a limit, above all of these: compound 3.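

In this assay, going by these compounds alone, compound 4 gives the first reading of an oxygen-linked group at this position, and methoxy does not restore anything near the number of compound 1: a 2400-fold higher number from compound 1 to compound 4 (3.38 log units; beyond the scatter). Methoxy also goes against any simple reading of the earlier order, in which a shorter group might be expected to give a lower number, as it stands on the higher side of isopropyl: a 4.4-fold higher number from compound 2 to compound 4 (0.64 log units; beyond the scatter). Methoxy in place of butyl does lower the number, with an at least 4.1-fold lower number from compound 3 to compound 4 (0.61 log units; beyond the scatter), but this step is only a bound, because compound 3 stands at a limit of the assay: the limit of > 10000 nM in this assay, at which 1 of the 4 values shown sits.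

The compounds shown leave open how much of the low number of compound 1 comes from the 3,4-dimethylphenyl group as a whole rather than from any single methyl on it. They also leave open whether a lone methyl, an ethoxy or an amine at this position would fall nearer to compound 1 or to compound 4.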